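This account rests on a few compounds, and the source may have more. Where it says the series, first, only, none or still open, it means among the compounds named here.

Measured compounds:
- compound 1, `CCC(CC)(CC(=O)Nc1cccc(OCc2ccc3cc(F)ccc3n2)c1)C(=O)O`, which in a functional assay on ileum (Cavia porcellus) for antagonist activity at cysteinyl leukotriene receptor (Homo sapiens) (on this read-out lower numbers stand for stronger inhibition and higher numbers for weaker inhibition), gives 2 nM
- compound 2, `CCC(CC)(CC(=O)Nc1cccc(OCc2ccc3ccc(C)cc3n2)c1)C(=O)O`, which in this assay gives 11 nM
- compound 3, `CCC(CC)(CC(=O)Nc1cccc(OCc2ccc3cc(C)ccc3n2)c1)C(=O)O`, which in this assay gives 24 nM

Compound 3 stands at the highest number of the three in this assay. Within the data shown here, its nearest neighbour is compound 2, whose value is lower; the two compounds carry their methyl at different positions of the shared core, and no single-site step connects them, so their values are simply placed side by side. Among the measured compounds shown here, the furthest is compound 1, and the one step that reaches compound 3 is a 12-fold higher number from compound 1 to compound 3 (1.08 log units; beyond the scatter).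

Compound 4, `CCC(CC)(CC(=O)Nc1cccc(OCc2ccc3cc(C)c(C)cc3n2)c1)C(=O)O`, differs from compound 3 by methyl in place of hydrogen on an aromatic carbon. For the measured compounds named here, no measured step adds a second methyl to this ring, so the only bearing comes from compound 1 to compound 3, where a methyl at this part of the core gave the large weakening seen in a 12-fold higher number from compound 1 to compound 3 (1.08 log units; beyond the scatter). A further methyl nearby is therefore expected to leave the number where it stands or to raise it modestly, rather than to bring it back toward compound 1. The step from compound 3 to compound 4 is expected to be a 1.7-fold higher number from compound 3 to compound 4 (0.22 log units; within the scatter). For compound 4 the estimate in this assay is 40 nM, with a range from 12 nM to 150 nM.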

Compound 4, half-maximal inhibitory concentration: 11 nM
Compound 4: the middle estimate sits 3.6-fold (0.56 log units) above what was measured, outside the stated range (below it).
By their numbers in this assay, from the lowest: compound 1; then compounds 2 and 4 (each within the scatter of the next); then compound 3.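

In this assay a second methyl on the ring, placed ortho to a methyl group, does not cost activity as the opening step suggested: there is a 2.2-fold lower number from compound 3 to compound 4 (0.34 log units; beyond the scatter) and the change counts as modest. The same doubly methylated compound reached from the other side shows no change at the digits printed from compound 2 to compound 4 (within the scatter) so the added methyl matters on compound 3 and does nothing measurable on compound 2, which means the effect of a methyl here depends on which methyl is already present, and the large rise seen on replacing fluoro with methyl, a 12-fold higher number from compound 1 to compound 3 (1.08 log units; beyond the scatter) cannot be read as a general penalty for a methyl at that place. No evidence is at hand that would explain this difference between the two additions.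

The compounds shown include no member with hydrogen at both places, so a single methyl cannot be set against hydrogen on the shared core, and the comparison of one methyl with two stays incomplete. From the compounds shown here alone, whether a chloro, methoxy or ethyl group in this place would track fluoro or methyl, and whether fluoro combined with a neighbouring methyl would hold the low number of compound 1, also remains open.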